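Swapping the Side Chain of Compound 2 for a Shorter One

The compounds below may be only part of what the source reports. "The series", "measured", "known", "first", "only" and "open" are said of these compounds alone.

Compound 1, `Cc1nc(N(C)c2ccc([Se]C#N)c(Cl)c2)c2ccccc2n1`, gives 12 nM in a functional assay on LoVo cells (Homo sapiens) for inhibition, read by MTT assay, with a stated time of 48 h; a lower number here means a stronger inhibitor, a higher number a weaker inhibitor.
Compound 2, `COc1ccc(N(C)c2nc(C)nc3ccccc23)cc1C(=O)OCCC[Se]C#N`, gives 854 nM in this assay.
Compound 3, `C[Se]c1ccc(N(C)c2nc(C3CC3)nc3ccccc23)cc1`, gives 11 nM in this assay.

Among the three measured compounds, compound 2 has the highest number, and so is the weakest inhibitor of the set: its gaps to compound 1 and to compound 3 both lie well beyond the scatter of repeated measurements. Compound 1 and compound 3 sit close to each other, so no order can be read between them.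

Compound 4, `COc1ccc(N(C)c2nc(C)nc3ccccc23)cc1OCCC[Se]C#N`, keeps the whole framework of compound 2 and changes only one side chain. (a group of 7 heavy atoms (4 carbon, 1 nitrogen, 1 oxygen, 1 selenium; no ring) in place of a group of 9 heavy atoms (5 carbon, 1 nitrogen, 2 oxygen, 1 selenium; no ring), on an aromatic carbon). Both the chain that leaves and the chain that enters sit ortho to a methoxy group and meta to a large group, so the change is in the chain itself, not its place.

Within the data shown here, no measured pair shows what a change of this kind does in this assay. The shortening is modest, and nothing in the measured set argues for a large swing. A small step is expected, with the number for compound 4 a little lower than for compound 2 but possibly within the scatter; the estimated step is a 1.4-fold lower number from compound 2 to compound 4 (0.15 log units; within the scatter). Compound 4 is therefore expected to give about 600 nM, with a likely range from 200 nM to 2000 nM.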

Compound 4, half-maximal inhibitory concentration: 921 nM
Estimate against measurement, compound 4: 1.5-fold (0.19 log units) below; the range from low to high includes it.
By their numbers in this assay, from the lowest: compounds 3 and 1 (each within the scatter of the next); then compounds 2 and 4 (each within the scatter of the next).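

In this assay the swap gives a 1.1-fold higher number from compound 2 to compound 4 (0.03 log units; within the scatter), so at this position, on an aromatic carbon ortho to a methoxy group, the two chains cannot be told apart by their numbers. Among these compounds, the earlier compounds could not show this, since no two of them differed in only one place; this pair is the first direct look at what a change in this chain does, and it shows that the group of 7 heavy atoms, which has no double bond outside aromatic rings, can stand in place of the group of 9 heavy atoms, which has one, with no change beyond the scatter. No measurement at hand accounts for this match between the two chains.

On these data alone, two chains at one position cannot show how far this tolerance extends, so it remains open whether a longer chain, or a chain ending in an amine or a carboxylic acid in place of the selenium-bearing end, would give a similar number. As far as these compounds go, it also remains open whether the same swap would give a similarly small step on a different core or in a different cell line.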